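This account rests on a few compounds, and the source may have more. Where it says the series, first, only, none or still open, it means among the compounds named here.

Values in an ADME assay on CEMx174 cells (Homo sapiens) for cytotoxicity; on this read-out higher numbers stand for lower toxicity in this test and lower numbers for higher toxicity in this test:
compound 1 `CCC1=C(C(=O)OCC2CCCCC2)C(c2cccc(O)c2)NC(=O)N1`: > 10000 nM (a limit)
compound 2 `CCC1=C(C(=O)OCC2CCCCC2)C(c2ccc([N+](=O)[O-])cc2)NC(=O)N1`: > 10000 nM (a limit)

Compound 2 has no number in this assay, only the limit > 10000 nM. Among the compounds with values here, the same holds for the only other measured compound, so the evidence so far is the limit of > 10000 nM in this assay, at which 2 of the 2 values shown sit.

Compound 3 `CCC1=C(C(=O)OCC2CCCCC2)C(c2ccc(NC)cc2)NC(=O)N1` keeps the core of compound 2 and carries methylamino in place of nitro on an aromatic carbon, para to a large group: methylamino in place of nitro on an aromatic carbon.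

Within the data shown here, the only measured step that bears on this change is a step that the two limits leave unreadable from compound 1 to compound 2. Among the measured compounds shown here, it concerns the same aromatic ring but gives no size to carry over, and no measured step involves methylamino. With both measured compounds at the limit, the working expectation in this assay is no step beyond the scatter and no direction, and another limit is the most likely result. The expected change is a number no higher from compound 2 to compound 3 (the limit leaves the size open). For compound 3 the estimated value is 10000 nM, with an expected range of 3000 nM to 30000 nM.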

Compound 3, half-maximal cytotoxic concentration: > 10000 nM
Compound 3 was reported as a limit; the forecaster's own chance of this, stated with the estimate: 75%; the middle value lies on the limit itself.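

In this assay compound 3 gives > 10000 nM, a limit and not a number. Within the data shown here, compound 1 and compound 2 also stand at limits, so no step to compound 3 can be read. The compounds shown leave open whether any of these aromatic ring changes alters the value at all, as the series offers only this: the limit of > 10000 nM in this assay, at which 3 of the 3 values shown sit.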